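Anilinoquinazoline series: methyl for bromo, still at the limit

This account rests on a few compounds, and the source may have more. Where it says the series, first, only, none or still open, it means among the compounds named here.

Measured so far:
Compound 1, `Fc1cccc(-c2nc(Nc3ccccc3)c3ccccc3n2)c1`, a limit in a functional assay on MCF7 cells (Homo sapiens) for cytotoxicity, read by MTT assay, with a stated time of 48 h; on this read-out higher numbers stand for weaker inhibition and lower numbers for stronger inhibition: compound 1 gives > 50000 nM.
Compound 2, `Fc1cccc(-c2nc(Nc3ccccc3Cl)c3cc(F)ccc3n2)c1`, a limit in this assay: compound 2 gives > 50000 nM.
Compound 3, `Fc1cccc(-c2nc(Nc3ccc(Br)cc3)c3cc(F)ccc3n2)c1`, a limit in this assay: compound 3 gives > 50000 nM.

Compound 3 stands only as a limit in this assay, and the two other values shown are limits as well, all sitting together on (the limit of > 50000 nM in this assay, at which 3 of the 3 values shown sit). Among the measured compounds shown here, the one step between measured compounds that differ in a single place, a step that the two limits leave unreadable from compound 2 to compound 3, cannot be read in size because both ends are limits. For the measured compounds named here, no measured step therefore gives a readable size for any change on the phenyl attached to the nitrogen.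

Compound 4 is `Cc1ccc(Nc2nc(-c3cccc(F)c3)nc3ccc(F)cc23)cc1`. It differs from compound 3 as follows: methyl in place of bromo on an aromatic carbon. Going by the values given here, there is no measured step of this kind to lean on; the only neighbouring step is the unreadable a step that the two limits leave unreadable from compound 2 to compound 3. Given that every value shown sits at the limit of > 50000 nM in this assay, at which 3 of the 3 values shown sit, compound 4 is expected to remain at or near that limit, with the step that the limit leaves unreadable from compound 3 to compound 4 expected to be no more than scatter. The estimate for compound 4 in this assay is 60000 nM, with a range from 15000 nM to 250000 nM.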

Compound 4, half-maximal inhibitory concentration: > 50000 nM
Compound 4: no number, only a limit (the forecaster's own chance of this, stated with the estimate: 75%); the middle value is on the limit's open side.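

Compound 4 gives > 50000 nM in this assay, a limit and not a number, so the steps to compound 4 from compound 2 and compound 3 cannot be read in size: the limit of > 50000 nM in this assay, at which 4 of the 4 values shown sit.

The compounds shown leave open which change to the shared core, if any, gives a measurable value in this assay.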